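Moving the methoxy group to a new ring position

The source may hold more compounds than are shown below. What is called first, only, known or untested is meant among the compounds shown, and "the series" means these compounds.

Three measured compounds share one core and differ only in the aryl group on a ring nitrogen. In a functional assay on MCF7 cells (Homo sapiens) for cytotoxicity, read by MTT assay, with a stated time of 24 h (on this read-out higher numbers stand for weaker inhibition and lower numbers for stronger inhibition), compound 1 `COc1ccccc1N1CCN(CC(=O)N2CCN(c3nnc(-c4ccc(C)cc4)c(-c4ccc(C)cc4)n3)CC2)CC1` gives 59400 nM, compound 2 `Cc1ccc(-c2nnc(N3CCN(C(=O)CN4CCN(c5ccccc5Cl)CC4)CC3)nc2-c2ccc(C)cc2)cc1` gives 859000 nM, and compound 3 `COc1cccc(N2CCN(CC(=O)N3CCN(c4nnc(-c5ccc(C)cc5)c(-c5ccc(C)cc5)n4)CC3)CC2)c1` gives 867000 nM, the highest of the three numbers, though compound 2 stands within the scatter of it (a 1.0-fold higher number from compound 2 to compound 3 (0.00 log units; within the scatter)). Both a 15-fold higher number from compound 1 to compound 3 (1.16 log units; beyond the scatter) and a 14-fold higher number from compound 1 to compound 2 (1.16 log units; beyond the scatter) are large. Compound 4 `COc1ccc(N2CCN(CC(=O)N3CCN(c4nnc(-c5ccc(C)cc5)c(-c5ccc(C)cc5)n4)CC3)CC2)cc1` differs from compound 3 by 4-methoxyphenyl in place of 3-methoxyphenyl on an amine nitrogen in a ring. Among the measured compounds shown here, no measured step covers this exact change; the one step that moved the methoxy group, a 15-fold higher number from compound 1 to compound 3 (1.16 log units; beyond the scatter), was large, so a shift of this kind has given a large step before, but its direction here is unknown. The expected step is a 1.2-fold lower number from compound 3 to compound 4 (0.09 log units; within the scatter), within the scatter. Compound 4 is therefore estimated at 700000 nM, with a range of 100000 nM to 3000000 nM.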

Compound 4, half-maximal inhibitory concentration: 53000 nM
Estimate against measurement, compound 4: 13-fold (1.12 log units) above, outside the stated range (below it).
By their numbers in this assay, from the lowest: compounds 4 and 1 (each within the scatter of the next); then compounds 2 and 3 (each within the scatter of the next).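

In this assay, the methoxy position does not shift the number steadily: moving it to give the 4-methoxyphenyl group produces a 16-fold lower number from compound 3 to compound 4 (1.21 log units; beyond the scatter), while a 1.1-fold lower number from compound 1 to compound 4 (0.05 log units; within the scatter) shows that the 2-methoxyphenyl and 4-methoxyphenyl groups give matching numbers. Among the three methoxy compounds, only the 3-methoxyphenyl group stands apart, though the 2-chlorophenyl group of compound 2 goes with it, as a 16-fold lower number from compound 2 to compound 4 (1.21 log units; beyond the scatter) shows. Nothing available explains this difference between positions. As far as these compounds go, whether a 4-ethoxyphenyl or 4-aminophenyl group would match the 4-methoxyphenyl group remains open.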